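Swapping the dichlorophenyl for fluorophenyl on the oxadiazoline core

The compounds below may be only part of what the source reports. "The series", "measured", "known", "first", "only" and "open" are said of these compounds alone.

Of the compounds shown here, two have been measured in a functional assay on PC-3 cells (Homo sapiens) for antiproliferative activity, read by MTT assay, tested at 5 uM; a lower number here means a weaker effect, a higher number a stronger effect of the compound at the concentration tested. Compound 1, with the structure `COc1cc(C2=NN(C(C)=O)C(c3cc(Cl)cc(Cl)c3)O2)cc(OC)c1OC`, gives 93.9% in this assay, the higher of the two numbers. Compound 2, with the structure `COc1cc(C(=O)N/N=C/c2c(Cl)cccc2Cl)cc(OC)c1OC`, gives 52.1% in this assay, a gap that lies beyond the usual scatter. These two compounds differ in more than one place, so their gap cannot be tied to a single change.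

Compound 3, with the structure `COc1cc(C2=NN(C(C)=O)C(c3cccc(F)c3)O2)cc(OC)c1OC`, has not yet been measured. It keeps the core of compound 1 and changes one group: 3-fluorophenyl in place of 3,5-dichlorophenyl on a saturated ring carbon. Without a measured pair that isolates this kind of change, the size of the step can only be guessed.

Since compound 1 already sits near the top of the scale with 93.9%, little room remains upward, and a smaller halogenated ring is expected to cost some effect. Compound 3 is therefore estimated to give 72% in this assay, within a range from 45% to 92%. This estimate means a step of a number 21.9 percentage points lower from compound 1 to compound 3 (beyond the scatter), expected to fall beyond the scatter.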

Compound 3, a percentage reported as inhibition, at one concentration (the size of the read-out at that concentration, not a potency): 43.5%
Estimate against measurement, compound 3: 28.5 percentage points above; the measured number lies below the stated range.
By their numbers in this assay, from the lowest: compounds 3 and 2 (each within the scatter of the next); then compound 1.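

Among the compounds shown here, this is the first pair that differs in one place only, so a size can now be put on what the group on this saturated ring carbon contributes in this assay. With the core of compound 1 held fixed, placing 3-fluorophenyl where 3,5-dichlorophenyl stood gives a step of a number 50.4 percentage points lower from compound 1 to compound 3 (beyond the scatter), which shows that the effect at this concentration depends strongly on which halogenated phenyl sits at this carbon. Nothing measured on these compounds accounts for a step of this size, so it stands as an observation without an explanation.

The change replaces chlorine with fluorine and also leaves one fewer substituent on the phenyl ring, and the compounds shown cannot separate these two parts; a 3-chlorophenyl or a 3,5-difluorophenyl at this carbon would tell them apart. As far as these compounds go, it also remains open whether this position tolerates anything other than a halogenated phenyl, such as a phenyl ring carrying an amine or a carboxylic acid.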